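Bromo in place of chloro: what to expect

A few compounds are considered here, and "the series" means these few. Any claim that something is new, unique, unknown or untested is made for them only; others in the source may bear on it.

Measured compounds:
Compound 1 `COc1cc(NCc2ccc(C)s2)ccc1-c1cnco1`: 34400 nM
Compound 2 `COc1cc(NCc2ccc(Cl)s2)ccc1-c1cnco1`: 43200 nM

Going by the values given here, in an ADME assay on Huh-7 cells (Homo sapiens) for cytotoxicity, read by MTT assay, with a stated time of 96 h (a higher number here means that more compound is tolerated, a lower number that less compound is tolerated), compound 2 gives 43200 nM, and compound 1, the only other compound measured, gives 34400 nM. These two values lie within the usual scatter of each other, so neither can be ranked above the other.

The next compound, compound 3 `COc1cc(NCc2ccc(Br)s2)ccc1-c1cnco1`, differs from compound 2 in a single group: bromo in place of chloro on an aromatic carbon. In words, this is bromo in place of chloro on an aromatic carbon, and the rest of the structure stays the same.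

The expectation rests on one measured step, a 1.3-fold higher number from compound 1 to compound 2 (0.10 log units; within the scatter). That step is chloro in place of methyl on an aromatic carbon, so it alters the same group that changes now. Among the compounds with values here, a single step is thin evidence, and no bromo compound has been measured yet. The expectation is therefore modest: no step beyond the scatter in this assay, in either direction. The expected move is a 1.1-fold lower number from compound 2 to compound 3 (0.02 log units; within the scatter). For compound 3 the estimated value is 41000 nM, with an expected range from 21000 nM to 80000 nM.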

Compound 3, half-maximal cytotoxic concentration: 39400 nM
Compound 3: middle estimate off by 1.0-fold (0.02 log units), on the high side; low and high end bracket the measured number.
By their numbers in this assay, from the lowest: compounds 1, 3 and 2 (each within the scatter of the next).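

Measured in this assay, the change from 5-chlorothiophen-2-yl to 5-bromothiophen-2-yl gives a 1.1-fold lower number from compound 2 to compound 3 (0.04 log units; within the scatter) and the comparison with the methyl compound gives a 1.1-fold higher number from compound 1 to compound 3 (0.06 log units; within the scatter) as its result. Three different groups have now been placed on the same aromatic carbon, next to the ring sulfur, and every step among compound 1, compound 2 and compound 3 stays within the scatter, so this assay cannot separate methyl, chloro and bromo at this position, and the earlier single step could not show that for bromo. Nothing available here explains why these three groups read alike.

The compounds shown leave open whether a clearly different group at this carbon, such as an amine, a carboxylic acid or a longer chain, would produce a step beyond the scatter or would also be indistinguishable from these three. From the compounds shown here alone, every change shown sits on this one carbon, so whether changes elsewhere on the shared core would move the number also remains open.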